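A few compounds are considered here, and "the series" means these few. Any claim that something is new, unique, unknown or untested is made for them only; others in the source may bear on it.

In a functional assay on DU-145 cells (Homo sapiens) for inhibition, read by trypan blue exclusion, with a stated time of 96 h (on this read-out higher numbers stand for weaker inhibition of growth and lower numbers for stronger inhibition of growth), three compounds have so far been measured. Compound 1 `CCOc1ccc(/C=C(\C(=O)c2ccc(Cl)cc2)S(=O)(=O)Cc2ccc(C)cc2)cc1OC` gives 10000 nM. Compound 2 `O=C(/C(=C\c1ccc(O)cc1)S(=O)(=O)Cc1ccc(F)cc1)c1ccc(Br)cc1` gives 10000 nM, which is level with compound 1 at the digits shown, the two together being the lowest numbers of the three. Compound 3 `COc1cc(OC)c(/C=C(\C(=O)c2ccc(Cl)cc2)S(=O)(=O)c2ccc(C)cc2)c(OC)c1` gives 25000 nM, the highest of the three; its gap to compound 2 lies beyond the usual scatter, so on this read-out compound 2 is the more strongly inhibiting of that pair.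

The next compound, compound 4 `COc1ccc(/C=C(\C(=O)c2ccc(Br)cc2)S(=O)(=O)Cc2ccc(F)cc2)cc1`, differs from compound 2 in one place: methyl in place of hydrogen on an oxygen on an aromatic ring. Among the measured compounds shown here, no pair of measured compounds differs by this one change alone, so there is no measured step to lean on. A change of this small size, with nothing in the measured set pointing either way, is expected to leave the number roughly where it is, within the scatter, so the step of a 1.2-fold higher number from compound 2 to compound 4 (0.08 log units; within the scatter) is estimated as essentially flat. Compound 4 is therefore expected to give about 12000 nM, with a likely range from 5000 nM to 30000 nM.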

Compound 4, concentration for 50% growth inhibition: 25000 nM
The estimate for compound 4 lay 2.1-fold (0.32 log units) below the measured number; the range from low to high includes it.
By their numbers in this assay, from the lowest: compounds 1 and 2 (each within the scatter of the next); then compounds 3 and 4 (each within the scatter of the next).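

Among the compounds shown here, until now no pair of compounds differed at this oxygen alone. In this assay the change from hydroxy to methoxy gives a 2.5-fold higher number from compound 2 to compound 4 (0.40 log units; beyond the scatter) and so weaker inhibition of growth, which shows that adding a single methyl at this place can move the number, at least with the rest of compound 2 held fixed. Nothing at hand explains the shift, so this remains one modest observation from one pair.

From the compounds shown here alone, it stays open whether the hydrogen on the oxygen matters as such or whether any added group would have the same result, a question that an amine in place of the hydroxy or a longer chain such as propoxy on the oxygen could help to answer. Going by these compounds, whether the same step appears when other parts of the molecule differ also stays open.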